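This account rests on a few compounds, and the source may have more. Where it says the series, first, only, none or still open, it means among the compounds named here.

Measured compounds:
compound 1 `O=C(NCc1ccccc1)c1cncc(Cl)n1`, an ADME assay on MDCK cells (Canis lupus familiaris) for cytotoxicity, read by microscopy, with a stated time of 6 days; a lower number here means that less compound is tolerated, a higher number that more compound is tolerated: "not determined" (no result reported)
compound 2 `CCCCCCCNc1nccnc1C(=O)NCc1ccccc1`, this assay: 100000 nM

Compound 1 stands without a number: in this assay compound 1 has "not determined" (no result reported), so its place on the scale is open. The only measured point in the series is compound 2, which in this assay gives 100000 nM, a high minimum cytotoxic concentration, so the compound is well tolerated by the cells over the stated time.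

Compound 3 `CCCCCCCNc1cncc(C(=O)NCc2ccccc2)n1` is not yet measured. It differs from compound 1 by heptylamino in place of chloro on an aromatic carbon. Among the compounds with values here, with no number for compound 1, the size and direction of the step from compound 1 to compound 3 in this assay cannot be given; there is no measured pair from which to take it. What can be said rests on compound 2, which carries the same heptylamino group and the same benzylamide on the shared core and is tolerated up to a high concentration.

On that basis compound 3 is expected to be tolerated to a similar degree, with an estimated minimum cytotoxic concentration of 50000 nM, in the range 10000 nM to 100000 nM.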

Compound 3, minimum cytotoxic concentration: 4000 nM
Beside the measured number, compound 3's estimate is 13-fold (1.10 log units) above it; the measured number lies below the stated range.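

In this assay, within the data shown here, compound 1 has "not determined" (no result reported), so no step from it to compound 3 can be read. The compounds shown leave open how far, and in which direction, exchanging chloro for heptylamino shifts the minimum cytotoxic concentration. Nothing shown bears on the result for compound 3.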